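Extending the amide tail of a naphthalene sulfonamide series

The compounds below may be only part of what the source reports. "The series", "measured", "known", "first", "only" and "open" are said of these compounds alone.

Measured so far:
compound 1, `Cc1ccccc1C(=O)Nc1ccc(S(=O)(=O)NC2CCN(C(=O)C3CCCC3)CC2)c2ccccc12`: 9.1 nM
compound 2, `Cc1ccccc1C(=O)Nc1ccc(S(=O)(=O)NC2CCN(C(=O)C3CNC3)CC2)c2ccccc12`: 1.5 nM

In an assay on L1.2 cells for binding affinity to C-C chemokine receptor type 8 (Homo sapiens) (a higher number here means a weaker inhibitor, a lower number a stronger inhibitor), compound 2 gives the lower of the two numbers shown, and its only neighbour is compound 1, a modest step away, a 6.1-fold lower number from compound 1 to compound 2 (0.78 log units; beyond the scatter). Compound 3, `CCN(CC)CCCC(=O)N1CCC(NS(=O)(=O)c2ccc(NC(=O)c3ccccc3C)c3ccccc23)CC1`, differs from compound 2 in one place: 3-(diethylamino)propyl in place of azetidin-3-yl on a carbonyl carbon. Going by the values given here, no measured pair mirrors this particular swap, so the sole guide is the step from compound 1 to compound 2, which changed the group on the same carbonyl carbon and moved the number by a modest amount. Because a 6.1-fold lower number from compound 1 to compound 2 (0.78 log units; beyond the scatter) shows that this position tolerates a change of group without a large shift, compound 3 is expected to stay in the same general range, with a slight loss as the more likely direction, an expected step of a 2.3-fold higher number from compound 2 to compound 3 (0.37 log units; beyond the scatter). The estimate for compound 3 in this assay is 3.5 nM, with a range from 0.9 nM to 14 nM.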

Compound 3, inhibition constant: 567 nM
For compound 3 the middle estimate is 160-fold (2.21 log units) below the measured one; measured number above the stated range.
By their numbers in this assay, from the lowest: compound 2; then compound 1; then compound 3.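

In this assay, this place on the carbonyl carbon proves far less forgiving than the first change suggested: moving to 3-(diethylamino)propyl gives a 380-fold higher number from compound 2 to compound 3 (2.58 log units; beyond the scatter) and a 62-fold higher number from compound 1 to compound 3 (1.79 log units; beyond the scatter), both large steps. Among these three compounds, the open chain of compound 3 goes with the highest number, while the ring-bearing cyclopentyl and azetidin-3-yl groups both give far lower numbers. A nitrogen in the group does not by itself secure a low number, since azetidin-3-yl and 3-(diethylamino)propyl both contain one.

The data shown offer no measured explanation for this loss. Going by these compounds, it remains open whether the chain length, the missing ring or the ethyl groups on the nitrogen matter most, and a shorter 2-(diethylamino)ethyl chain or a plain butyl chain could help separate these features.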